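The source may report more compounds than this note shows. Statements on the series, on what has been measured and on what is new or still open speak of the compounds shown alone.

Compound 3 `Oc1ccc(-c2cc(-c3ccsc3)cc(-c3cccc(O)c3)n2)cc1` gives, in a functional assay on DU-145 cells (Homo sapiens) for cytotoxicity, read by CCK-8 assay (a lower number here means a stronger inhibitor, a higher number a weaker inhibitor), a value of 2230 nM, the highest of the two numbers shown. Its nearest neighbour is compound 1 `Oc1ccc(-c2cc(-c3cccs3)cc(-c3ccc(O)cc3)n2)cc1`, which gives 2190 nM, within the scatter of compound 3. Compound 2 `Oc1ccc(-c2cc(-c3ccsc3)cc(-c3ccccc3O)n2)cc1` sits at the limit of > 50000 nM in this assay, at which 1 of the 3 values shown sits, and gives only > 50000 nM. Among the measured compounds shown here, the one measured step, an at least 22-fold lower number from compound 2 to compound 3 (1.35 log units; beyond the scatter), concerns a different change of the hydroxyphenyl group. Compound 4 `Oc1ccc(-c2cc(-c3ccsc3)cc(-c3ccc(O)cc3)n2)cc1` differs from compound 3 by 4-hydroxyphenyl in place of 3-hydroxyphenyl on an aromatic carbon. For the measured compounds named here, no measured step tracks this change directly. Compound 1 already carries a 4-hydroxyphenyl group at that position and its value lies within the scatter of compound 3. A step of a 1.1-fold lower number from compound 3 to compound 4 (0.05 log units; within the scatter) in this assay is therefore expected, nothing beyond the scatter. Compound 4 is estimated at 2000 nM, between 800 nM and 5000 nM.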

Compound 4, half-maximal inhibitory concentration: 2060 nM
Compound 4: middle estimate off by 1.0-fold (0.01 log units), on the low side, and the stated range covers the measured number.
By their numbers in this assay, from the lowest: compounds 4, 1 and 3 (each within the scatter of the next). At a limit, above all of these: compound 2.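

In this assay, the 4-hydroxyphenyl and 3-hydroxyphenyl groups next to the ring nitrogen cannot be told apart, with a 1.1-fold lower number from compound 3 to compound 4 (0.03 log units; within the scatter). Thiophen-3-yl in place of thiophen-2-yl also leaves the number within the scatter, with a 1.1-fold lower number from compound 1 to compound 4 (0.03 log units; within the scatter). Only the 2-hydroxyphenyl group stands apart, with an at least 24-fold lower number from compound 2 to compound 4 (1.38 log units; beyond the scatter), and compound 2 remains a limit, not a number: the limit of > 50000 nM in this assay, at which 1 of the 4 values shown sits.

The compounds shown leave open whether the hydroxyl group matters at this position at all. Going by these compounds, a methoxy group, an amine or a fluorine in its place remains untested here.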